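From Trifluoromethyl to Methoxy: An Expected Antiproliferative Shift

The source may hold more compounds than are shown below. What is called first, only, known or untested is meant among the compounds shown, and "the series" means these compounds.

Compound 1 `COc1cc(-n2cnc3ccc(-c4ccc(C(F)(F)F)cc4)cc32)cc(OC)c1OC` gives 760 nM in a functional assay on MCF7 cells (Homo sapiens) for antiproliferative activity, read by MTT assay, with a stated time of 72 h (a higher number here means a weaker inhibitor, a lower number a stronger inhibitor), the higher of the two numbers recorded so far. Compound 2 `COc1cc(-n2cnc3ccc(-c4cccc(C)c4)cc32)cc(OC)c1OC` gives 360 nM in this assay, and the step of a 2.1-fold lower number from compound 1 to compound 2 (0.32 log units; beyond the scatter) came with 3-methylphenyl in place of 4-(trifluoromethyl)phenyl. Compound 3 `COc1ccc(-c2ccc3ncn(-c4cc(OC)c(OC)c(OC)c4)c3c2)cc1` differs from compound 1 by methoxy in place of trifluoromethyl on an aromatic carbon. Among the compounds with values here, only that single measured step bears on this change, and it was modest, so a modest lowering at most is expected here, a 1.7-fold lower number from compound 1 to compound 3 (0.23 log units; within the scatter). Compound 3 is therefore estimated at 450 nM, with a range from 200 nM to 1100 nM.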

Compound 3, half-maximal inhibitory concentration: 210 nM
Estimate against measurement, compound 3: 2.1-fold (0.33 log units) above; the measured number falls inside the stated range.
By their numbers in this assay, from the lowest: compounds 3 and 2 (each within the scatter of the next); then compound 1.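

In this assay methoxy in place of trifluoromethyl gives a 3.6-fold lower number from compound 1 to compound 3 (0.56 log units; beyond the scatter) and so, at this aromatic carbon, the change now has a direct measurement of its own. The 4-methoxyphenyl and 3-methylphenyl groups cannot be separated, with a 1.7-fold lower number from compound 2 to compound 3 (0.23 log units; within the scatter) here, so among these three compounds only compound 1 stands apart. Nothing available accounts for the step.

On these data alone, what an amine or a carboxylic acid would do at this same place remains open, as does whether a longer chain on the oxygen would keep the number near that of compound 3.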